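The compounds below may be only part of what the source reports. "The series", "measured", "known", "first", "only" and "open" are said of these compounds alone.

Of the compounds shown here, two from this series have been measured so far. Compound 1 `Cc1ccccc1-c1ccc(-c2nnc(N(C)Cc3ccc4nccn4c3)o2)cc1` was tested in an assay on isolated protein for inhibition of tyrosine-protein kinase receptor UFO (Homo sapiens), read by LC-MS (on this read-out lower numbers stand for stronger inhibition and higher numbers for weaker inhibition), where compound 1 gives 631 nM. Compound 2 `Cc1nn(C)c(C)c1-c1ccc(-c2nnc(N(C)Cc3ccc4nccn4c3)o2)c(F)c1` carries a fluoro group and a differently substituted aromatic ring on the same core; in this assay compound 2 gives 1260 nM. Among the compounds with values here, compound 2 sits alongside compound 1 on this read-out: the two values lie within the scatter of each other, so neither can be called the weaker of the pair, and no step between them can be drawn.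

The next compound, compound 3 `COc1cc(-c2c(C)nn(C)c2C)ccc1-c1nnc(N(C)Cc2ccc3nccn3c2)o1`, differs from compound 2 in one place: methoxy in place of fluoro on an aromatic carbon. Within the data shown here, no pair of measured compounds shows what such an exchange does on this core, so there is nothing in the data to support a step in either direction. Compound 3 is therefore expected to land close to compound 2, with a step of a 1.3-fold lower number from compound 2 to compound 3 (0.10 log units; within the scatter) that stays within the scatter. The estimate for compound 3 in this assay is 1000 nM, with a range from 300 nM to 4000 nM.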

Compound 3, half-maximal inhibitory concentration: 794 nM
Estimate against measurement, compound 3: 1.3-fold (0.10 log units) above, within the range that was stated.
By their numbers in this assay, from the lowest: compounds 1, 3 and 2 (each within the scatter of the next).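

Within the data shown here, the exchange of fluoro for methoxy, on an aromatic carbon ortho to a large group and meta to the 1,3,5-trimethyl-1H-pyrazol-4-yl group, gives the first step that can be read on this core. In this assay the reading is a 1.6-fold lower number from compound 2 to compound 3 (0.20 log units; within the scatter), so the two compounds cannot be told apart. Methoxy brings two heavy atoms and one hydrogen-bond acceptor where fluoro has one heavy atom and no acceptor, yet the values of the pair stay within the scatter, and nothing measured in the series bears on the reason for this result.

As far as these compounds go, what an amine, a carboxylic acid or a longer alkoxy chain would do on this aromatic carbon remains open, as does whether any group here can differ from fluoro by more than the scatter. Also open, from the compounds shown here alone, is whether the same exchange would read alike on the core of compound 1, which does not carry the 1,3,5-trimethyl-1H-pyrazol-4-yl group.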